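The source may report more compounds than this note shows. Statements on the series, on what has been measured and on what is new or still open speak of the compounds shown alone.

Of the compounds shown here, three built on one shared core have so far been tested in an in vitro functional assay on cells for agonist activity at Bombesin receptor subtype-3 (Mus musculus), read by luminescence and calcium flux; a higher number here means that more compound is needed for the effect, a lower number that less compound is needed. Compound 1 `CCCCc1cnc(Cc2ccc(-c3ccccc3C(=O)O)cc2)[nH]1` carries a butyl chain and reaches only the limit of the assay, > 10000 nM, so for compound 1 no number is known. Compound 3 `CCCCc1cnc(C(Cc2ccc(-c3ccccc3C(=O)O)cc2)C(C)C)[nH]1`, which also carries a butyl chain, gives 2240 nM in this assay. Compound 2 `COc1ccc(Cc2cnc(CCc3ccc(-c4ccccc4C(=O)O)cc3)[nH]2)cc1`, with a 4-methoxybenzyl group in place of that chain, gives 513 nM in this assay, the lowest number among those measured, and the number for compound 3 stands beyond the scatter above it.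

Compound 4 `O=C(O)c1ccccc1-c1ccc(CCc2ncc(CCC3CCCCC3)[nH]2)cc1` has not yet been measured. It differs from compound 2 in one place: cyclohexylmethyl in place of 4-methoxyphenyl on a saturated chain carbon bound to an aromatic carbon. The aromatic ring of compound 2 is thus exchanged for a non-aromatic ring of the same size. The two compounds that carry a saturated chain at this end of the molecule, compound 1 and compound 3, both sit at higher numbers than compound 2, which points toward a loss on moving to a saturated ring as well. A moderate rise in the number is therefore expected from compound 2 to compound 4, a step of a 2.5-fold higher number from compound 2 to compound 4 (0.40 log units; beyond the scatter). For compound 4 in this assay the estimate is 1300 nM, with a likely range from 350 nM to 5000 nM.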

Compound 4, half-maximal effective concentration: 33 nM
For compound 4 the middle estimate is 39-fold (1.60 log units) above the measured one; measured number below the stated range.
By their numbers in this assay, from the lowest: compound 4; then compound 2; then compound 3. At a limit, above all of these: compound 1.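

The exchange of 4-methoxyphenyl for cyclohexylmethyl, on a saturated chain carbon bound to an aromatic carbon, gives a 16-fold lower number from compound 2 to compound 4 (1.19 log units; beyond the scatter) in this assay, so this end of the molecule clearly has a strong influence on the number, and an aromatic ring is not required there for a low one. Among the compounds shown here, this is also the first pair that differs in one place, so it gives the first direct reading of a change at this position; the earlier compounds differ from one another in more than one place and could not show this. The change alters several things together, since the aromatic ring becomes a non-aromatic one, the oxygen of the methoxy group is lost, and the chain to the ring is read differently, and nothing shown says which of these accounts for the step.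

The compounds shown leave open whether the ring type, the methoxy group or the chain matters most, a question that a 2-phenylethyl group at this place could help to separate. Going by these compounds, it also remains open how a longer chain, or an amine on the cyclohexane ring, would behave here.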